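The compounds below may be only part of what the source reports. "The series", "measured", "known", "first", "only" and "open" are said of these compounds alone.

Going by the values given here, compound 2 `O=C(Nc1ccc(-n2ncc3c(Cl)cccc32)cc1)Nc1ccc(Cl)c(C(F)(F)F)c1` is the one compound with a number in a functional assay on OS-RC-2 cells (Homo sapiens) for cytotoxicity, read by MTT assay, with a stated time of 72 h; a higher number here means a weaker inhibitor, a lower number a stronger inhibitor: it gives 3100 nM. Compound 1 `O=C(Nc1ccc(-n2ncc3c(C(F)(F)F)cccc32)cc1)Nc1ccc(Cl)c(C(F)(F)F)c1` reaches only a limit in this assay, > 32000 nM, (the limit of > 32000 nM in this assay, at which 1 of the 2 values shown sits). Among the compounds with values here, the sole measured step is an at least 10-fold lower number from compound 1 to compound 2 (1.01 log units; beyond the scatter). Compound 3 `O=C(Nc1ccc(-n2ncc3c(Br)cccc32)cc1)Nc1ccc(Cl)c(C(F)(F)F)c1` differs from compound 2 by bromo in place of chloro on an aromatic carbon. Within the data shown here, that measured step put chloro in place of trifluoromethyl; the present change exchanges one halogen for another, and no measured step covers it. The expected step is therefore within the scatter, a 1.2-fold lower number from compound 2 to compound 3 (0.09 log units; within the scatter). Compound 3 is estimated at 2500 nM, between 1000 nM and 6500 nM.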

Compound 3, half-maximal inhibitory concentration: 9900 nM
For compound 3 the middle estimate is 4.0-fold (0.60 log units) below the measured one; measured number outside the range, above it.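

In this assay, exchanging one halogen for another on this aromatic carbon is not a neutral change: it gives a 3.2-fold higher number from compound 2 to compound 3 (0.50 log units; beyond the scatter). Bromo still does better here than trifluoromethyl, with an at least 3.2-fold lower number from compound 1 to compound 3 (0.50 log units; beyond the scatter), so the three groups rank chloro, bromo, trifluoromethyl, going from the lowest number upward. The last place in that order rests on a limit of the assay for compound 1, not on a number: the limit of > 32000 nM in this assay, at which 1 of the 3 values shown sits. The compounds shown leave open whether fluoro, methyl, methoxy or an amine at this place would give a lower number than chloro.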